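Pyrrolidinyl to morpholinyl amide: notes toward compound 3

The compounds below may be only part of what the source reports. "The series", "measured", "known", "first", "only" and "open" are said of these compounds alone.

Measured so far:
compound 1 `Cc1cc(-c2nnc3n2CCCCC3)c(C)n1-c1ccc(F)cc1` gives 121 nM
compound 2 `Cc1cccc(-n2cnc3cc(C(=O)N4CCCC4)ccc32)c1` gives 383 nM

In an assay on isolated protein for inhibition of 15-hydroxyprostaglandin dehydrogenase [NAD(+)] (Homo sapiens), read by fluorescence, with a stated time of 15 min (on this read-out lower numbers stand for stronger inhibition and higher numbers for weaker inhibition), compound 2 stands at the higher of the two numbers, with 383 nM. Compound 1 sits beyond the scatter from it, with a lower number, at 121 nM. The two compounds share no common scaffold, so their difference says nothing about any single change on compound 2.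

Compound 3 `Cc1cccc(-n2cnc3cc(C(=O)N4CCOCC4)ccc32)c1` keeps the whole of compound 2 apart from the amide ring: the change is morpholin-4-yl in place of pyrrolidin-1-yl on a carbonyl carbon. The ring gains one hetero atom and one ring member, and the amide otherwise stays as it is. Within the data shown here, no pair of measured compounds shows this or a related change, so there is no measured step to lean on. The expectation is that the step of a 1.3-fold higher number from compound 2 to compound 3 (0.12 log units; within the scatter) is small, with no clear direction beyond the scatter, and a modest move to a higher number is as plausible as none. Compound 3 is expected to give about 500 nM. The range for compound 3 is expected to run from 180 nM to 1500 nM.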

Compound 3, half-maximal inhibitory concentration: 3040 nM
Beside the measured number, compound 3's estimate is 6.1-fold (0.78 log units) below it; the whole stated range lies below it.
By their numbers in this assay, from the lowest: compound 1; then compound 2; then compound 3.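

In this assay, the amide ring on the carbonyl carbon proves to be a sensitive place, as morpholin-4-yl in place of pyrrolidin-1-yl gives a 7.9-fold higher number from compound 2 to compound 3 (0.90 log units; beyond the scatter) and moves the series towards weaker inhibition. Among these compounds, compound 1 shares no scaffold with compound 2, so the earlier numbers held no information on this position; this is the first step with a single point of difference, and it shows that changing only the ring on the carbonyl carbon can carry the number beyond the scatter. No measurement shown speaks to the reason for this rise.

The step changes ring size and ring oxygen together, so the compounds shown do not say which of the two goes with the higher number; piperidin-1-yl on the same carbonyl carbon, a six-membered non-aromatic ring without the oxygen, would separate them. Also open, from the compounds shown here alone, is whether the number can fall below that of compound 2 with a different amine on this carbonyl carbon, such as azetidin-1-yl or dimethylamino.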